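The source may hold more compounds than are shown below. What is called first, only, known or untested is meant among the compounds shown, and "the series" means these compounds.

The measured compounds:
compound 1 `COc1ccc(-n2nncc2CN2C(=O)C3(C(C#N)=C(N)Oc4c(N)cc5nc6ccccc6nc5c43)c3ccccc32)cc1` — in a functional assay on A549 cells (Homo sapiens) for antiproliferative activity, read by MTT assay, with a stated time of 48 h (a higher number here means a weaker inhibitor, a lower number a stronger inhibitor), compound 1 gives > 50000 nM, a limit of the assay rather than a number.
compound 2 `CCc1cccc(C)c1-n1nncc1CN1C(=O)C2(C(C#N)=C(N)Oc3c(N)cc4nc5ccccc5nc4c32)c2ccccc21` — in this assay compound 2 gives > 50000 nM, likewise a limit of the assay.
compound 3 `N#CC1=C(N)Oc2c(N)cc3nc4ccccc4nc3c2C12C(=O)N(Cc1cnnn1-c1ccc(F)c(Cl)c1)c1ccccc12` — in this assay compound 3 gives 43400 nM.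

Within the data shown here, compound 3 thus stands as the only compound with a number in this assay; the other two values sit at the limit (the limit of > 50000 nM in this assay, at which 2 of the 3 values shown sit). The steps to it, an at least 1.1-fold lower number from compound 1 to compound 3 (0.06 log units; that floor lies within the scatter) and an at least 1.1-fold lower number from compound 2 to compound 3 (0.06 log units; that floor lies within the scatter), show only a floor that lies within the scatter, and the step that the two limits leave unreadable from compound 1 to compound 2 cannot be read at all. Compound 4 `N#CC1=C(N)Oc2c(N)cc3nc4ccccc4nc3c2C12C(=O)N(Cc1cnnn1-c1ccc(Cl)cc1[N+](=O)[O-])c1ccccc12` differs from compound 3 by 4-chloro-2-nitrophenyl in place of 3-chloro-4-fluorophenyl on an aromatic nitrogen. Three different aryl groups on this nitrogen have so far given either a limit or a number close to it, so no step beyond the scatter is expected for a fourth. Compound 4 is therefore expected to give about 50000 nM in this assay, between 20000 nM and 120000 nM. The expected step is a 1.2-fold higher number from compound 3 to compound 4 (0.06 log units; within the scatter), and there is a fair chance that only a limit will be reported.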

Compound 4, half-maximal inhibitory concentration: > 50000 nM
Compound 4 gave a limit, no number; the forecaster's own chance of this, stated with the estimate: 55%; the middle value lies on the limit itself.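

In this assay, among these compounds, the one new step that can be read is an at least 1.1-fold higher number from compound 3 to compound 4 (0.06 log units; that floor lies within the scatter), so the change from 3-chloro-4-fluorophenyl to 4-chloro-2-nitrophenyl can be given only as a floor, not as a size; the steps from compound 1 and compound 2 to compound 4 cannot be read, as each joins two limits. A fourth aryl group on this aromatic nitrogen, now one that carries two hydrogen-bond acceptors, also gives no number. Compound 3 remains the only compound with a number, and the limit now holds most of the set: the limit of > 50000 nM in this assay, at which 3 of the 4 values shown sit.

All four groups shown on this nitrogen are substituted phenyl rings, leaving open what a plain alkyl chain, a pyridine ring or a phenyl ring carrying an amine or a carboxylic acid would give. Also open, as far as these compounds go, is whether a change to the shared core would give a number well clear of the limit.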